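Aryl replacement at the shared core, antiproliferative read-out

The source may hold more compounds than are shown below. What is called first, only, known or untested is meant among the compounds shown, and "the series" means these compounds.

Measured compounds:
compound 1, `COc1cc(-n2cnc3ccc(-c4ccc(Cl)cc4)cc32)cc(OC)c1OC`: 1320 nM
compound 2, `COc1cccc(-c2ccc3ncn(-c4cc(OC)c(OC)c(OC)c4)c3c2)c1`: 1610 nM
compound 3, `COc1cc(-n2cnc3ccc(-c4ccccc4)cc32)cc(OC)c1OC`: 2290 nM

In a functional assay on MCF7 cells (Homo sapiens) for antiproliferative activity, read by MTT assay, with a stated time of 72 h (on this read-out lower numbers stand for stronger inhibition and higher numbers for weaker inhibition), compound 2 gives 1610 nM, the second highest of the three numbers. The steps of a 1.2-fold higher number from compound 1 to compound 2 (0.09 log units; within the scatter) and a 1.4-fold higher number from compound 2 to compound 3 (0.15 log units; within the scatter) set it between the other two, and a 1.7-fold higher number from compound 1 to compound 3 (0.24 log units; within the scatter) is likewise within the scatter, so the three aryl groups tried so far give numbers that cannot be told apart.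

Compound 4, `COc1cc(-n2cnc3ccc(-c4ccc(O)cc4)cc32)cc(OC)c1OC`, differs from compound 2 by 4-hydroxyphenyl in place of 3-methoxyphenyl on an aromatic carbon. Within the data shown here, the steps bearing on this are those that exchange the same aryl group, a 1.2-fold higher number from compound 1 to compound 2 (0.09 log units; within the scatter) and a 1.4-fold higher number from compound 2 to compound 3 (0.15 log units; within the scatter), both within the scatter; no measured step covers a hydroxyl group. A step of a 1.1-fold higher number from compound 2 to compound 4 (0.05 log units; within the scatter) is therefore expected, none beyond the scatter. For compound 4 the estimate is 1800 nM, with a range from 700 nM to 4500 nM.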

Compound 4, half-maximal inhibitory concentration: 4160 nM
Compound 4: the middle estimate sits 2.3-fold (0.36 log units) below what was measured, and the stated range covers the measured number.
By their numbers in this assay, from the lowest: compounds 1, 2, 3 and 4 (each within the scatter of the next, the first and the last beyond it).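

In this assay, among these compounds, this aryl position gives the only steps beyond the scatter: 4-hydroxyphenyl in place of 3-methoxyphenyl gives a 2.6-fold higher number from compound 2 to compound 4 (0.41 log units; beyond the scatter), and hydroxy in place of chloro gives a 3.2-fold higher number from compound 1 to compound 4 (0.50 log units; beyond the scatter). Hydroxy in place of hydrogen gives a 1.8-fold higher number from compound 3 to compound 4 (0.26 log units; within the scatter), so compound 4 separates from compound 1 and compound 2 but not from compound 3. No data on hand account for these steps.

From the compounds shown here alone, whether an amine or a carboxylic acid on this aryl ring would track with hydroxy or with chloro stays open.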